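A few compounds are considered here, and "the series" means these few. Any claim that something is new, unique, unknown or untested is made for them only; others in the source may bear on it.

Working notes on the series, read-out a physicochemical assay for solubility, read by nephelometry, measured as kinetic solubility, at pH 2.0; a higher number here means a more soluble compound, a lower number a less soluble compound:

- Compound 1 `CC(C)(C)c1cc(C(=O)Nc2cccc(CN)c2)n(Cc2ccccc2)n1`: > 100 ug/mL
- Compound 2 `CC(C)(C)c1cc(C(=O)Nc2nc(CNS(C)(=O)=O)cs2)n(Cc2ccccc2)n1`: 3.1 ug/mL

Compound 1 stands at > 100 ug/mL, which is a limit of the assay and not a number. Compound 3 `CC(C)(C)c1cc(C(=O)Nc2ccccc2)n(Cc2ccccc2)n1` has not yet been measured. It carries hydrogen in place of aminomethyl on an aromatic carbon, meta to a large group (hydrogen in place of aminomethyl on an aromatic carbon). Among the compounds with values here, no measured step isolates this change, so the expectation rests on little. Within the data shown here, compound 2 also lacks the aminomethyl group and reads 3.1 ug/mL, the only true number available as a guide. The estimated change, an at least 20-fold lower number from compound 1 to compound 3 (1.30 log units; beyond the scatter), is expected to be a fall well beyond the scatter in this assay, though its size stays uncertain with a limit at the starting end. For compound 3 the expected value is 5 ug/mL, with an estimated range of 1 ug/mL to 25 ug/mL.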

Compound 3, solubility: 1.6 ug/mL
The estimate for compound 3 lay 3.1-fold (0.49 log units) above the measured number, within the range that was stated.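

In this assay, hydrogen in place of aminomethyl on an aromatic carbon now has a step of its own, with the rest of the core unchanged: an at least 62-fold lower number from compound 1 to compound 3 (1.79 log units; beyond the scatter). Within the data shown here, this is the first comparison that differs in one place, so the large drop, beyond the scatter, belongs to this single change and not to any other part of the structure. Its full size cannot be read, as compound 1 stands at > 100 ug/mL, a limit of the assay and not a number: the limit of > 100 ug/mL in this assay, at which 1 of the 3 values shown sits.

The compounds shown leave open whether the step depends on the amine itself or would also appear with a hydroxymethyl group or a carboxylic acid on the same aromatic carbon. As far as these compounds go, a longer chain such as aminoethyl at this place also remains open, including whether it would give a true number in this assay.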